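This account rests on a few compounds, and the source may have more. Where it says the series, first, only, none or still open, it means among the compounds named here.

Working notes on the hydroxamic acid series. Compound 1 `CCN(C(=O)c1cc(C(C)C)c(O)cc1O)c1cccc(NC(=O)CCCCCCC(=O)NO)c1` is the amide bearing an ethyl group on the amide-type nitrogen; in a functional assay on A549 cells (Homo sapiens) for inhibition, read by sulforhodamine B assay, with a stated time of 48 h (a higher number here means a weaker inhibitor of growth, a lower number a stronger inhibitor of growth), compound 1 gives 1590 nM. Compound 2 `CC(C)c1cc(C(=O)N(C)c2ccc(NC(=O)CCCCCCC(=O)NO)cc2)c(O)cc1O` carries a methyl group there and a different substitution pattern; in this assay compound 2 gives 770 nM. Of the two numbers recorded, compound 1 stands highest, and the gap to compound 2 lies beyond the usual scatter. Going by the values given here, no single-change step between measured compounds is available.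

Compound 3 `CC(C)c1cc(C(=O)Nc2cccc(NC(=O)CCCCCCC(=O)NO)c2)c(O)cc1O` differs from compound 1 by one change, (hydrogen in place of ethyl on an amide-type nitrogen). Among the compounds with values here, with no measured single-change step to lean on, the direction is uncertain; a modest shift is expected, most likely a slight lowering of the number, though a result within the scatter would not surprise. Compound 3 is therefore estimated at 1200 nM, with a range of 500 nM to 3000 nM, which corresponds to an expected step of a 1.3-fold lower number from compound 1 to compound 3 (0.12 log units; within the scatter).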

Compound 3, concentration for 50% growth inhibition: > 10000 nM
Compound 3 ended at the assay's limit; the forecaster's own chance of this, stated with the estimate: 3%; at least 8.3-fold (0.92 log units) between middle value and limit.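

In this assay, going by these compounds alone, the amide-type nitrogen whose other neighbours are an aromatic carbon and a carbonyl carbon proves sensitive to its substituent, a point the earlier compounds could not show, since no single-change step was available: hydrogen in place of ethyl gives an at least 6.2-fold higher number from compound 1 to compound 3 (0.79 log units; beyond the scatter). Compound 3 gives > 10000 nM, which is a limit of the assay and not a number. The step therefore has a lower bound but no measured size: the limit of > 10000 nM in this assay, at which 1 of the 3 values shown sits.

How the number runs with the size of the group on this nitrogen stays open, since the core of compound 1 is shown here only with ethyl and hydrogen, and a propyl chain or a benzyl group there would test this. Compound 2 carries a methyl group on this nitrogen but differs from compound 1 in more than one place, so it does not settle the question.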